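Replacing phenyl with methoxycarbonyl in a level pair

The compounds below may be only part of what the source reports. "The series", "measured", "known", "first", "only" and "open" are said of these compounds alone.

In a functional assay on NB-4 cells (Homo sapiens) for cytotoxicity, read by CCK-8 assay, with a stated time of 24 h (on this read-out higher numbers stand for weaker inhibition and lower numbers for stronger inhibition), compound 1 (`C=CC(=O)N1C(=O)CC(c2ccc(Br)cc2)Sc2ccccc21`) gives 59400 nM and compound 2 (`C=CC(=O)N1C(=O)CC(c2ccc(-c3ccccc3)cc2)Sc2ccccc21`) gives 57700 nM. These two values lie within the scatter of each other, so compound 2 stands level with compound 1. Compound 3 (`C=CC(=O)N1C(=O)CC(c2ccc(C(=O)OC)cc2)Sc2ccccc21`) keeps the shared core but carries methoxycarbonyl in place of phenyl on an aromatic carbon, para to a large group (methoxycarbonyl in place of phenyl on an aromatic carbon). Within the data shown here, only one measured step bears on this place. That step, a 1.0-fold lower number from compound 1 to compound 2 (0.01 log units; within the scatter), put phenyl in place of bromo and stayed within the scatter. Among the measured compounds shown here, with this single step as the only guide, no change beyond the scatter is expected in this assay for the new swap. The estimated step is a 1.0-fold lower number from compound 2 to compound 3 (0.02 log units; within the scatter) here. For compound 3 the expected value is 55000 nM, with an estimated range of 25000 nM to 110000 nM.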

Compound 3, half-maximal inhibitory concentration: 24400 nM
The estimate for compound 3 lay 2.3-fold (0.35 log units) above the measured number; the whole stated range lies above it.
By their numbers in this assay, from the lowest: compound 3; then compounds 2 and 1 (each within the scatter of the next).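

In this assay bromo and phenyl stood level at this place, but methoxycarbonyl gives a 2.4-fold lower number from compound 2 to compound 3 (0.37 log units; beyond the scatter) and a 2.4-fold lower number from compound 1 to compound 3 (0.39 log units; beyond the scatter) on the same aromatic carbon, a modest change in both cases. So what sits on this carbon can move the number beyond the scatter, and a ring is not needed there, since methoxycarbonyl has none and brings hydrogen-bond acceptors that phenyl lacks. No measurement here explains the shift.

The compounds shown leave open whether the oxygen atoms of methoxycarbonyl matter or only its overall shape. A carboxylic acid, an acetyl group or an amine on this carbon would help separate these possibilities, and a longer ester would show whether the lower number holds as the chain grows.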